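This account rests on a few compounds, and the source may have more. Where it says the series, first, only, none or still open, it means among the compounds named here.

In a functional assay on FaDu cells (Homo sapiens) for cytotoxicity, read by MTT assay, with a stated time of 72 h (a higher number here means that more compound is tolerated, a lower number that less compound is tolerated), compound 1 `COc1ccc(NC(=O)C(=O)c2cn(C(C)C)c3ccccc23)nn1` gives 2270 nM and compound 2 `CC(C)Oc1ccc(NC(=O)C(=O)c2cn(C(C)C)c3ccccc23)cn1` gives 408 nM. Compound 3 `CC(C)n1cc(C(=O)C(=O)Nc2ccc(C(F)(F)F)nc2)c2ccccc21` reaches only > 10000 nM, which is a limit of the assay and not a number. Compound 4 `CC(C)n1cc(C(=O)C(=O)Nc2cccnc2)c2ccccc21` carries hydrogen in place of trifluoromethyl on an aromatic carbon. Among the compounds with values here, one measured step bears on this same carbon, where trifluoromethyl replaced isopropoxy and produced a large change, an at least 24-fold higher number from compound 2 to compound 3 (1.38 log units; beyond the scatter). Within the data shown here, no compound with hydrogen at this carbon has a measured value, so the size of the next step is uncertain. Losing the trifluoromethyl is expected to give back part of that large change, and the expected step, toward a lower number, is an at least 2.5-fold lower number from compound 3 to compound 4 (0.39 log units; beyond the scatter). Compound 4 is estimated at 4000 nM, within a range of 800 nM to 15000 nM.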

Compound 4, concentration lethal to 50% of the cells: > 10000 nM
Compound 4: no number, only a limit (the forecaster's own chance of this, stated with the estimate: 30%); at least 2.5-fold (0.39 log units) between middle value and limit.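

In this assay, hydrogen in place of isopropoxy also gives a large step, an at least 24-fold higher number from compound 2 to compound 4 (1.38 log units; beyond the scatter), so the rise seen with trifluoromethyl does not depend on trifluoromethyl itself. Pyridin-3-yl in place of 6-methoxypyridazin-3-yl gives an at least 4.4-fold higher number from compound 1 to compound 4 (0.64 log units; beyond the scatter), which suggests that the alkoxy groups of compound 1 and compound 2 may matter. The step between compound 3 and compound 4 cannot be read because both sit at the same limit: the limit of > 10000 nM in this assay, at which 2 of the 4 values shown sit.

As far as these compounds go, whether an amine or a longer alkoxy chain on this carbon would bring the number back toward that of compound 2 remains open.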